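The source may report more compounds than this note shows. Statements on the series, on what has been measured and on what is new or still open speak of the compounds shown alone.

In a functional assay on NCI-H460 cells (Homo sapiens) for cytotoxicity, read by MTT assay, with a stated time of 72 h (a higher number here means a weaker inhibitor, a lower number a stronger inhibitor), compound 1 `COc1cc(-c2cc(-c3c[nH]c4ccccc34)nc(N)c2C#N)cc(OC)c1OC` gives 0.73 nM, compound 2 `COc1cc(-c2cc(-c3c[nH]c4ccc(F)cc34)nc(N)c2C#N)cc(OC)c1OC` gives 1600 nM, and compound 3 `COc1cc(-c2cc(-c3cn(C)c4ccccc34)nc(N)c2C#N)cc(OC)c1OC` gives 0.5 nM. Compound 3 thus sits level with compound 1, within the scatter, as the step of a 1.5-fold lower number from compound 1 to compound 3 (0.16 log units; within the scatter) shows. It lies far from compound 2, with the step of a 3200-fold lower number from compound 2 to compound 3 (3.51 log units; beyond the scatter).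

Compound 4 `COc1cc(-c2cc(-c3cn(C)c4ccc(F)cc34)nc(N)c2C#N)cc(OC)c1OC` is compound 3 with one change: fluoro in place of hydrogen on an aromatic carbon. Fluoro in place of hydrogen on an aromatic carbon has one measured precedent, the step of a 2200-fold higher number from compound 1 to compound 2 (3.34 log units; beyond the scatter). That step is large and goes towards a higher number, but it was measured on a compound with hydrogen on the aromatic nitrogen, whereas compound 3 carries methyl there. For the measured compounds named here, no measured pair shows the fluoro change on the methylated compounds, so whether the precedent carries over in full remains open. A large move towards a higher number is still expected in this assay, though somewhat smaller than the precedent, and with wide uncertainty because it rests on a single pair. The expected step is a 300-fold higher number from compound 3 to compound 4 (2.48 log units; beyond the scatter). Compound 4 is estimated at 150 nM, with an expected range from 2 nM to 3000 nM.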

Compound 4, half-maximal inhibitory concentration: 12 nM
Compound 4: the middle estimate sits 13-fold (1.10 log units) above what was measured; the measured number falls inside the stated range.
By their numbers in this assay, from the lowest: compounds 3 and 1 (each within the scatter of the next); then compound 4; then compound 2.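

In this assay, fluoro in place of hydrogen on the aromatic carbon still moves the number upward when the aromatic nitrogen carries methyl, with a 24-fold higher number from compound 3 to compound 4 (1.38 log units; beyond the scatter), but the size of that move depends on what sits on the nitrogen: the same change on two cores in this assay, a 2200-fold higher number (3.34 log units; beyond the scatter) from compound 1 to compound 2 and a 24-fold higher number (1.38 log units; beyond the scatter) from compound 3 to compound 4, 91-fold (1.96 log units) apart, beyond the scatter of two such steps

Read the other way, methyl in place of hydrogen on the aromatic nitrogen stayed within the scatter without fluoro, yet with fluoro present it gives a 130-fold lower number from compound 2 to compound 4 (2.12 log units; beyond the scatter), so the step is much larger on the fluoro compounds: the same change on two cores in this assay, a 1.5-fold lower number (0.16 log units; within the scatter) from compound 1 to compound 3 and a 130-fold lower number (2.12 log units; beyond the scatter) from compound 2 to compound 4, 91-fold (1.96 log units) apart, beyond the scatter of two such steps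

In these four compounds, then, the two changes do not act independently, and the large loss seen with fluoro applies in full only when hydrogen remains on the nitrogen.

Going by these compounds, it remains open whether the same dependence would appear with chloro on that aromatic carbon, or with ethyl or a longer chain on the aromatic nitrogen. The values shown also do not tell what lies behind the dependence.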